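The source may hold more compounds than are shown below. What is called first, only, known or untested is meant among the compounds shown, and "the series" means these compounds.

In an ADME assay on HeLa cells (Homo sapiens) for cytotoxicity, read by crystal violet staining, with a stated time of 72 h (a higher number here means that more compound is tolerated, a lower number that less compound is tolerated), compound 1 `CCOC(=O)c1cc(CCCOc2ccc(-c3noc(C(F)(F)F)n3)cc2F)on1` gives 60200 nM. Compound 2 `CCOC(=O)c1cc(CCCOc2c(OC)cc(-c3noc(C(F)(F)F)n3)cc2[N+](=O)[O-])on1` reads > 100000 nM, which is a limit of the assay and not a number. Compound 3 `Cc1cc(-c2noc(C(F)(F)F)n2)cc(C)c1OCCCc1cc(-c2ccccc2)no1` reads > 100000 nM, again only a limit. This is the limit of > 100000 nM in this assay, at which 2 of the 3 values shown sit. Compound 4 `CCNC(=O)c1cc(CCCOc2c(C)cc(-c3noc(C(F)(F)F)n3)cc2C)on1` differs from compound 3 by ethylcarbamoyl in place of phenyl on an aromatic carbon. Among the compounds with values here, no measured pair shows this change alone. In this assay, a small move toward less compound tolerated is expected, and the estimated step of an at least 1.1-fold lower number from compound 3 to compound 4 (0.07 log units; that floor lies within the scatter) reflects that. The expectation leans on compound 1, which carries an ethyl ester rather than phenyl at this place and gives 60200 nM. For compound 4 the expected value is 85000 nM, within an estimated range of 35000 nM to 100000 nM.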

Compound 4, half-maximal cytotoxic concentration: > 100000 nM
Compound 4 was reported as a limit; the forecaster's own chance of this, stated with the estimate: 55%; at least 1.1-fold (0.07 log units) between middle value and limit.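

Compound 3 and compound 4 both read as limits and not as numbers, so no step can be read between them: the limit of > 100000 nM in this assay, at which 3 of the 4 values shown sit.

From the compounds shown here alone, whether ethylcarbamoyl in place of phenyl on an aromatic carbon changes the result in this assay stays open.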